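The source may report more compounds than this note shows. Statements on the series, on what has been measured and on what is new or still open speak of the compounds shown alone.

Compound 3 `Cc1cccc(N2C(=O)[C@H]3[C@H](ON4[C@@H]3C(=O)N(C)[C@@]43C[C@H](C)CC[C@H]3C(C)C)C2=O)c1` gives 57.6% in a functional assay, read by spectrophotometry, with a stated time of 2 h, tested at 2.5 mg/mL (on this read-out lower numbers stand for a weaker effect and higher numbers for a stronger effect at the one concentration tested), the top of the three numbers shown, though compound 2 `CC(C)[C@@H]1CC[C@@H](C)C[C@@]12N(C)C(=O)[C@@H]1[C@H]3C(=O)N(C)C(=O)[C@H]3ON12` at 57.2% lies within the scatter of it, while compound 1 `CC(C)[C@@H]1CC[C@@H](C)C[C@@]12N(C)C(=O)[C@@H]1[C@H]3C(=O)NC(=O)[C@H]3ON12` gives 38% in this assay. Compound 4 `Cc1ccc(N2C(=O)[C@H]3[C@H](ON4[C@@H]3C(=O)N(C)[C@@]43C[C@H](C)CC[C@H]3C(C)C)C2=O)c(C)c1` differs from compound 3 in one place: 2,4-dimethylphenyl in place of 3-methylphenyl on an amide-type nitrogen in a ring. Going by the values given here, the measured steps that bear on this nitrogen are a number 19.6 percentage points higher from compound 1 to compound 3 (beyond the scatter) and a number 0.4 percentage points higher from compound 2 to compound 3 (within the scatter); no measured step exchanges 3-methylphenyl for another substituted phenyl there. Since methyl and 3-methylphenyl on this nitrogen sit within the scatter of each other, no step beyond the scatter is expected, a number 0.6 percentage points lower from compound 3 to compound 4 (within the scatter). Compound 4 is therefore estimated at 57%, within the range 42% to 72%.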

Compound 4, a percentage reported as activity, at one concentration (the size of the read-out at that concentration, not a potency): 65.6%
Compound 4: the middle estimate sits 8.6 percentage points below what was measured; the measured number falls inside the stated range.
By their numbers in this assay, from the lowest: compound 1; then compounds 2, 3 and 4 (each within the scatter of the next).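

At this amide-type nitrogen in this assay, putting 2,4-dimethylphenyl in place of 3-methylphenyl gives a number 8 percentage points higher from compound 3 to compound 4 (within the scatter) and putting it in place of methyl gives a number 8.4 percentage points higher from compound 2 to compound 4 (within the scatter) so neither exchange separates these groups. Only the exchange for the amide hydrogen stands out, with a number 27.6 percentage points higher from compound 1 to compound 4 (beyond the scatter) and this now holds for all three groups on the nitrogen. No measured evidence accounts for these numbers. Going by these compounds, whether an amine or a carboxylic acid on the phenyl ring, or a longer chain on this nitrogen, would depart from these numbers remains open.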